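Moving the Methyl Around the Pyridine Ring

The source may hold more compounds than are shown below. What is called first, only, known or untested is meant among the compounds shown, and "the series" means these compounds.

For the measured compounds named here, compound 2 `Cc1ccc(-c2cc(F)cc(-n3nnc(-c4ccccn4)n3)c2)cn1` gives 36 nM in an assay for binding affinity to metabotropic glutamate receptor 5 (Rattus norvegicus) (a higher number here means a weaker inhibitor, a lower number a stronger inhibitor), the lower of the two numbers so far; its neighbour compound 1 `Cc1ncccc1-c1cc(F)cc(-n2nnc(-c3ccccn3)n2)c1` gives 45 nM in this assay. Going by the values given here, the only step yet measured, a 1.3-fold lower number from compound 1 to compound 2 (0.10 log units; within the scatter), shifted the methyl on the pyridine ring and changed little. Compound 3 `Cc1cncc(-c2cc(F)cc(-n3nnc(-c4ccccn4)n3)c2)c1` differs from compound 2 by 5-methylpyridin-3-yl in place of 6-methylpyridin-3-yl on an aromatic carbon, another shift of the same methyl. Because that earlier step was a 1.3-fold lower number from compound 1 to compound 2 (0.10 log units; within the scatter), no step beyond the scatter is expected here, a 1.1-fold higher number from compound 2 to compound 3 (0.05 log units; within the scatter). Compound 3 is therefore estimated at 40 nM, within a range from 15 nM to 120 nM.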

Compound 3, inhibition constant: 272 nM
Estimate against measurement, compound 3: 6.8-fold (0.83 log units) below; the whole stated range lies below it.
By their numbers in this assay, from the lowest: compounds 2 and 1 (each within the scatter of the next); then compound 3.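

Where the methyl sits on the pyridine ring matters in this assay after all, with a 7.6-fold higher number from compound 2 to compound 3 (0.88 log units; beyond the scatter) and a 6.0-fold higher number from compound 1 to compound 3 (0.78 log units; beyond the scatter) as the two steps that show it. The atoms stay the same, so the arrangement alone separates 5-methylpyridin-3-yl from the other two groups, which lie within the scatter of each other. Nothing available explains why this arrangement gives the weaker binding. On these data alone, it remains open whether the methyl itself matters at this spot. A methoxy group or an amine there, or a pyridine ring with no methyl at all, would help to answer that.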